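This account rests on a few compounds, and the source may have more. Where it says the series, first, only, none or still open, it means among the compounds named here.

Of the compounds shown here, three built on a shared core have numbers so far in a functional assay on NCI-H460 cells (Homo sapiens) for inhibition, read by sulforhodamine B assay, with a stated time of 72 h; on this read-out higher numbers stand for weaker inhibition and lower numbers for stronger inhibition. Compound 1 `CCNC(=O)c1nnn(-c2cc(C(C)C)c(O)cc2O)c1-c1ccc(CN2CCC[C@H](O)C2)cc1` gives 70 nM and compound 2 `CCNC(=O)c1nnn(-c2cc(C(C)C)c(O)cc2O)c1-c1ccc(CN2CCC(N(C)C)CC2)cc1` gives 120 nM. The step of a 1.7-fold higher number from compound 1 to compound 2 (0.23 log units; within the scatter) does not separate them. Compound 3 `CCNC(=O)c1nnn(-c2cc(C(C)C)c(O)cc2O)c1-c1ccc(CNCC2CCCCC2)cc1` gives 2.1 nM, the lowest number of the three and the strongest inhibition, well clear of both others.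

Compound 4 `CCNC(=O)c1nnn(-c2cc(C(C)C)c(O)cc2O)c1-c1ccc(CNCCCN(CC)CC)cc1` keeps everything in compound 3 except one group: 2-(diethylamino)ethyl in place of cyclohexyl on a saturated chain carbon bound to an amine nitrogen. A ring of carbon only thus gives way to an open chain with no ring.

Within the data shown here, no measured step makes this exact swap. The closest evidence comes from steps that replace the whole (cyclohexylmethyl)amino group: a 33-fold lower number from compound 1 to compound 3 (1.52 log units; beyond the scatter) and a 57-fold lower number from compound 2 to compound 3 (1.76 log units; beyond the scatter). Both are large, so changes in this part of the molecule can move the number far. Compound 2, which also contains an amine group outside its ring, gives 120 nM, though compound 1 gives a number within the scatter of it without one. Compound 4 retains the chain amine nitrogen of compound 3, so a rise smaller than those large steps seems most likely.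

The expected step is a 7.1-fold higher number from compound 3 to compound 4 (0.85 log units; beyond the scatter), towards weaker inhibition. For compound 4 the estimated value is 15 nM, with an expected range from 3 nM to 70 nM.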

Compound 4, half-maximal inhibitory concentration: 412 nM
Compound 4: the middle estimate sits 27-fold (1.44 log units) below what was measured; the whole stated range lies below it.
By their numbers in this assay, from the lowest: compound 3; then compounds 1 and 2 (each within the scatter of the next); then compound 4.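

In this assay, putting 2-(diethylamino)ethyl in place of cyclohexyl, on a saturated chain carbon bound to an amine nitrogen, gives a 200-fold higher number from compound 3 to compound 4 (2.29 log units; beyond the scatter), the largest step among these compounds, so keeping the chain amine nitrogen is not enough to hold the low number of compound 3. Among these compounds, the change also carries compound 4 past the two compounds with piperidine-based groups, with a 3.4-fold higher number from compound 2 to compound 4 (0.54 log units; beyond the scatter) and a 5.9-fold higher number from compound 1 to compound 4 (0.77 log units; beyond the scatter), two modest steps that leave (cyclohexylmethyl)amino as the only group here reaching the low end of the range. Nothing measured on these compounds gives a reason for this large rise.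

The swap removes the carbon ring and adds a diethylamino nitrogen in a single move, so the compounds shown cannot tell which of the two changes carries the step. A plain hexyl chain would have no ring and no added nitrogen, while a cyclohexyl ring bearing a dimethylamino group would keep the ring and add the nitrogen, and each would pull those two changes apart.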